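Amino and methoxy on the benzyl of compound 2

The source may report more compounds than this note shows. Statements on the series, on what has been measured and on what is new or still open speak of the compounds shown alone.

In a functional assay on HCT-116 cells (Homo sapiens) for inhibition, read by CCK-8 assay, with a stated time of 48 h (a lower number here means a stronger inhibitor, a higher number a weaker inhibitor), compound 1 (`COc1ccc(CN(C(=O)CSC(=S)N2CCc3cc(OC)ccc32)c2cc(OC)c(OC)c(OC)c2)cc1`) gives 9810 nM. Compound 2 (`COc1cc(N(Cc2ccc(C)cc2)C(=O)CSC(=S)N2CCN(C(=O)OC(C)(C)C)CC2)cc(OC)c1OC`) gives only a limit, > 20000 nM. Its place on the numbers is the limit of > 20000 nM in this assay, at which 1 of the 2 values shown sits, so compound 2 has no exact value to serve as a starting point.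

Compound 3 (`COc1ccc(CN(C(=O)CSC(=S)N2CCN(C(=O)OC(C)(C)C)CC2)c2cc(OC)c(OC)c(OC)c2)cc1N`) keeps the rest of compound 2 and changes one group: 3-amino-4-methoxyphenyl in place of 4-methylphenyl on a saturated chain carbon bound to an amide-type nitrogen. In words, 3-amino-4-methoxyphenyl stands in place of 4-methylphenyl on a saturated chain carbon bound to an amide-type nitrogen. The same difference can be read as 4-methylbenzyl to 3-amino-4-methoxybenzyl.

Within the data shown here, no measured step tests this change, so the expectation is tentative. A step beyond the scatter towards stronger inhibition in this assay is expected, with a real chance that compound 3 also stops at a limit. The closest guide is compound 1, whose benzyl group also carries a methoxy and which gives 9810 nM. The expected step is an at least 6.6-fold lower number from compound 2 to compound 3 (0.82 log units; beyond the scatter). For compound 3 the estimated value is 3000 nM, with an expected range of 400 nM to 18000 nM.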

Compound 3, half-maximal inhibitory concentration: 352 nM
Estimate against measurement, compound 3: 8.5-fold (0.93 log units) above; measured number outside the range, below it.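

In this assay, among these compounds, 3-amino-4-methoxyphenyl in place of 4-methylphenyl on a saturated chain carbon bound to an amide-type nitrogen gives an at least 56-fold lower number from compound 2 to compound 3 (1.75 log units; beyond the scatter), the first reading of a single change, and it shows that the number responds strongly to what this aryl group carries. Going by these compounds, the true size of the step remains open on one side because compound 2 stands at a limit and not at a number: the limit of > 20000 nM in this assay, at which 1 of the 3 values shown sits. Among the compounds shown here, compound 1 differs from compound 2 and from compound 3 in more than one place, so it cannot be used to read this change, and this single step is the only evidence for the position.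

Amino and methoxy enter together, so the compounds shown do not separate their shares; 3-aminophenyl and 4-methoxyphenyl, each alone in the same place, would divide the step between them. On these data alone, whether the amino group itself is needed also stays open, and a hydroxy group or an acetylamino group in its place would test this in this assay.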